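Dropping One Hydroxy from Compound 3

The source may hold more compounds than are shown below. What is called first, only, known or untested is meant among the compounds shown, and "the series" means these compounds.

Compound 3 `O=C1/C(=C/c2ccccc2)CCC/C1=C\c1ccc(O)c(O)c1` gives the highest number of the three measured in an assay on isolated protein for inhibition of Alpha glucosidase (Homo sapiens), with stated times of 5 min and 15 min, tested at 50 uM; a lower number here means less inhibition, a higher number more inhibition at the concentration tested (going by the name of the read-out): compound 3 gives 90.7%. Compound 2 `O=C1/C(=C/c2ccccc2)CCC/C1=C\c1ccccc1Cl` gives 43%, which lies beyond the scatter below compound 3, and compound 1 `Cc1ccc(/C=C2\CCC/C(=C\c3ccccc3)C2=O)cc1` gives 34.1%, also beyond the scatter below compound 3. Compound 4 `O=C1/C(=C/c2ccccc2)CCC/C1=C\c1cccc(O)c1` differs from compound 3 by hydrogen in place of hydroxy on an aromatic carbon, the hydroxy that leaves sitting ortho to the remaining hydroxy group. Among the measured compounds shown here, the only measured step, a number 8.9 percentage points higher from compound 1 to compound 2 (within the scatter), concerns rings without any hydroxy and does not bear on this change; no measured step removes a hydroxy. Both hydroxy-free compounds stand well below compound 3. Losing one of two hydroxy groups is therefore expected to lower inhibition partly, a step of a number 30.7 percentage points lower from compound 3 to compound 4 (beyond the scatter). Compound 4 is estimated at 60%, within 35% to 85%.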

Compound 4, a percentage reported as inhibition, at one concentration (the size of the read-out at that concentration, not a potency): 65.1%
Beside the measured number, compound 4's estimate is 5.1 percentage points below it, and the stated range covers the measured number.
By their numbers in this assay, from the lowest: compounds 1 and 2 (each within the scatter of the next); then compound 4; then compound 3.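

Removing the hydroxy group ortho to a hydroxy group does not abolish the effect in this assay: hydrogen in its place gives a number 25.6 percentage points lower from compound 3 to compound 4 (beyond the scatter). The one remaining hydroxy still keeps inhibition apart from the rings without any hydroxy, with a number 22.1 percentage points higher from compound 2 to compound 4 (beyond the scatter) and a number 31 percentage points higher from compound 1 to compound 4 (beyond the scatter). Nothing measured here explains the size of these steps. Still open, as far as these compounds go, is whether the other hydroxy, kept alone, would do the same, and whether a methoxy or an amine could stand in place of the remaining hydroxy.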